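A Chloropropyl Amide in Place of the Acyl Urea

The source may report more compounds than this note shows. Statements on the series, on what has been measured and on what is new or still open speak of the compounds shown alone.

Compound 2 `CCCCC(OC)c1cccc(NC(=O)NC(=O)CC)c1` carries a methyl ether and an acyl urea on its aromatic core. In a functional assay on M21 cells (Homo sapiens) for antiproliferative activity, with a stated time of 48 h (on this read-out higher numbers stand for weaker inhibition and lower numbers for stronger inhibition), compound 2 gives > 100000 nM, which is a limit of the assay and not a number. Its parent alcohol, compound 1 `CCCCC(O)c1cccc(NC(=O)NC(=O)CC)c1`, has hydrogen in place of that methyl on the oxygen. In this assay compound 1 gives > 100000 nM, again a limit. The step that the two limits leave unreadable from compound 1 to compound 2 cannot be read because both values sit at the limit of > 100000 nM in this assay, at which 2 of the 3 values shown sit. A third measured compound, compound 3 `CC(C)(C)c1ccc(NC(=O)CCl)cc1`, has a different core and a chloroacetamide; in this assay compound 3 gives 5400 nM.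

The unmeasured compound 4 `CCCCC(OC)c1cccc(NC(=O)CCCCl)c1` differs from compound 2 by 3-chloropropyl in place of propanoylamino on a carbonyl carbon. Within the data shown here, no measured step touches this change: the only measured step is unreadable, and compound 3 shares neither core nor chain with compound 4, so its value shows only that a chloroalkyl amide on another core can give a measurable number. The expected step of an at least 2.5-fold lower number from compound 2 to compound 4 (0.39 log units; beyond the scatter) is therefore a guess rather than a derivation. Compound 4 is estimated at 40000 nM, with a range from 8000 nM to 200000 nM, and a fair chance that this assay again reports only a limit.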

Compound 4, half-maximal inhibitory concentration: > 100000 nM
Compound 4: only a limit was reported; the forecaster's own chance of this, stated with the estimate: 45%; at least 2.5-fold (0.39 log units) between middle value and limit.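

In this assay compound 4 gives > 100000 nM, which is a limit of the assay and not a number. The step from compound 2 to compound 4 therefore cannot be read, because neither value is an actual number: the limit of > 100000 nM in this assay, at which 3 of the 4 values shown sit. The compounds shown leave open whether 3-chloropropyl in place of propanoylamino on a carbonyl carbon changes this read-out at all.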